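From Chloro to Cyano on an Aromatic Carbon

A few compounds are considered here, and "the series" means these few. Any claim that something is new, unique, unknown or untested is made for them only; others in the source may bear on it.

Compound 1 `O=C1NC(=O)N(/N=C/c2ccc(-c3ccc(Cl)c(Cl)c3)o2)C1O`: 72 mg/kg
Compound 2 `O=C1NC(=O)N(/N=C/c2ccc(-c3ccc(Cl)cc3)o2)C1O`: > 1000 mg/kg (a limit, not a number)

In a functional assay on the whole organism for activation, with Mus musculus as the target, with a stated time of 60 min (a higher number here means that more compound is needed for the effect, a lower number that less compound is needed), compound 2 stands at a limit of the assay, > 1000 mg/kg. Compound 3 `N#Cc1ccc(-c2ccc(/C=N/N3C(=O)NC(=O)C3O)o2)cc1` differs from it by cyano in place of chloro on an aromatic carbon, para to a large group. Among the measured compounds shown here, the only measured guide is an at least 13-fold higher number from compound 1 to compound 2 (1.14 log units; beyond the scatter), a large step that also swaps a group on an aromatic carbon. That step shows the number can move far, but it involves a different swap, so only a modest move towards a lower number is expected, and another limit would be no surprise. The estimated change is an at least 2.0-fold lower number from compound 2 to compound 3 (0.30 log units; that floor lies within the scatter). For compound 3, the expected value is 500 mg/kg, with an estimated range of 100 mg/kg to 1500 mg/kg.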

Compound 3, dose for half-maximal effect: 156 mg/kg
The estimate for compound 3 lay 3.2-fold (0.51 log units) above the measured number; measured number inside the range.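

With cyano in place of chloro on an aromatic carbon, para to a large group, the result in this assay moves from a limit to a real number: an at least 6.4-fold lower number from compound 2 to compound 3 (0.80 log units; beyond the scatter). This shows that a single change at this position can bring a measurable dose. The step is only a floor, because compound 2 stands at a limit and not at a number: the limit of > 1000 mg/kg in this assay, at which 1 of the 3 values shown sits.

Going by these compounds, it remains open whether this result is particular to cyano, or whether an amine or a carboxylic acid at the same position would also give a measurable dose.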